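The compounds below may be only part of what the source reports. "The series", "measured", "known", "first", "only" and "open" are said of these compounds alone.

Measured in an ADME assay on BHK-21 cells (Mesocricetus auratus) for cytotoxicity, read by MTT assay, with a stated time of 96 h (on this read-out higher numbers stand for lower toxicity in this test and lower numbers for higher toxicity in this test), so far:
compound 1 `Cc1ccc(/N=N/c2ccc(NCCCN(C)C)cc2)cc1` gives > 100000 nM (a limit of the assay)
compound 2 `CN(C)CCCN(/N=N/c1ccccc1)c1cccc(C(F)(F)F)c1` gives 49000 nM
compound 3 `Brc1cccc(/N=N/N2CCCCC2)c1` gives > 100000 nM (a limit of the assay)

Compound 1 stands at the limit of > 100000 nM in this assay, at which 2 of the 3 values shown sit, and so has a limit rather than a number. Going by the values given here, compound 2 is the only compound with a number.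

Compound 4 `CN(C)CCCNc1ccc(/N=N/c2ccc([N+](=O)[O-])cc2)cc1` has yet to be measured. Going to it from compound 1 puts nitro in place of methyl on an aromatic carbon, para to a large group nitro in place of methyl on an aromatic carbon and no measured pair in the series shows this change. The expectation therefore rests on little. Compound 2, at 49000 nM, shows that a number can be reached in this series. In this assay a small move toward lower numbers is expected, possibly none beyond the usual scatter, and another result at the limit is quite possible. The expected step is an at least 1.6-fold lower number from compound 1 to compound 4 (0.22 log units; that floor lies within the scatter) and remains a rough estimate. For compound 4 the estimated value is 60000 nM with an expected range of 20000 nM to 100000 nM in this test.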

Compound 4, half-maximal cytotoxic concentration: > 100000 nM
Compound 4: a limit, no number; the forecaster's own chance of this, stated with the estimate: 45%; middle value at least 1.6-fold (0.22 log units) from the limit.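

No step can be read between compound 1 and compound 4, because both stand at a limit of the assay and neither has a number: the limit of > 100000 nM in this assay, at which 3 of the 4 values shown sit. As far as these compounds go, whether nitro in place of methyl on an aromatic carbon shifts the read-out at all remains open.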